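From 3-bromophenoxy to 3-chlorophenoxy: one halogen exchange

The compounds below may be only part of what the source reports. "The series", "measured", "known", "first", "only" and "open" are said of these compounds alone.

Two compounds sharing one core have entries so far in a functional assay on MDA-MB-231 cells (Homo sapiens) for antiproliferative activity, read by MTT assay, with a stated time of 72 h (on this read-out lower numbers stand for stronger inhibition and higher numbers for weaker inhibition), on record. For compound 1 (`NC1=NC2(CCOCC2)N(OCCCOc2ccc(Cl)cc2)C(N)=N1`) the entry reads "not determined" (no result reported) and gives no number. Within the data shown here, compound 2 (`NC1=NC2(CCOCC2)N(OCCCOc2cccc(Br)c2)C(N)=N1`) gives 400 nM in this assay and so supplies the only number available, which leaves it unranked against anything else.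

Compound 3 (`NC1=NC2(CCOCC2)N(OCCCOc2cccc(Cl)c2)C(N)=N1`) has yet to be measured. Its difference from compound 2 (chloro in place of bromo on an aromatic carbon) is chloro in place of bromo on an aromatic carbon, meta to a large group, which also reads as 3-bromophenoxy to 3-chlorophenoxy. Compound 1 carries a chloro group too, but without a number it offers no guide.

Among the measured compounds shown here, the series holds no measured step that shows what such an exchange does, so the only anchor is compound 2 at 400 nM in this read-out. With so small a change, no shift beyond the usual scatter is expected, in either direction. The expected 1.1-fold higher number from compound 2 to compound 3 (0.02 log units; within the scatter) is accordingly treated as no real change. In this assay compound 3 is estimated at 420 nM with an expected range of 190 nM to 950 nM for repeated measurements.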

Compound 3, half-maximal inhibitory concentration: 1020 nM
For compound 3 the middle estimate is 2.4-fold (0.39 log units) below the measured one; the measured number lies above the stated range.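

In this assay, a 2.6-fold higher number from compound 2 to compound 3 (0.41 log units; beyond the scatter) gives the series its first readable step at this aromatic carbon, meta to a large group, and it favours bromo over chloro for this pair. The exchange replaces one heavy atom with one heavy atom, with no ring, hydrogen-bond donor, hydrogen-bond acceptor or net charge on either side, yet the step lies beyond the usual scatter, so the two halogens cannot be treated as interchangeable here. No accompanying measurement is available to account for the difference between these two compounds.

The entry for compound 1 reads "not determined" (no result reported), so it cannot be compared with compound 3, and the effect of moving the chloro group to another ring position remains unresolved. Also open, on these data alone, is whether the step from bromo to chloro is part of a wider trend at this aromatic carbon, which could be tested with fluoro, iodo, methyl or an amine there, and whether the preference for bromo would persist with a longer chain.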